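From cyclopropylamino to cyclobutylamino: a small step expected

The source may report more compounds than this note shows. Statements on the series, on what has been measured and on what is new or still open speak of the compounds shown alone.

For the measured compounds named here, in a physicochemical assay for solubility, in phosphate buffer, at pH 6.8 (a lower number here means a less soluble compound, a higher number a more soluble compound), compound 1 `CCn1c(NC2CC2)nc2ccsc2c1=O` gives 430 ug/mL and stands highest of the two numbers so far. Going by the values given here, the only other measured compound, compound 2 `CCn1c(NC(C)C)nc2c(-c3cncnc3)csc2c1=O`, gives 18 ug/mL in this assay and lies lower by a gap beyond the scatter. The next compound to follow is compound 3 `CCn1c(NC2CCC2)nc2ccsc2c1=O`, which carries cyclobutyl in place of cyclopropyl on a nitrogen on an aromatic ring, with the change counted as cyclobutyl in place of cyclopropyl on a nitrogen on an aromatic ring and the rest of the structure kept. Among the compounds with values here, no measured pair isolates a change of this kind, so the expectation rests only on how small the change is. A modest fall is expected, a 1.6-fold lower number from compound 1 to compound 3 (0.20 log units; within the scatter) within the scatter rather than beyond it. Compound 3 is estimated at 270 ug/mL with an expected range from 120 ug/mL to 520 ug/mL in this measurement.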

Compound 3, solubility: 6.3 ug/mL
For compound 3 the middle estimate is 43-fold (1.63 log units) above the measured one, outside the stated range (below it).
By their numbers in this assay, from the lowest: compound 3; then compound 2; then compound 1.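

In this assay, cyclobutyl in place of cyclopropyl on a nitrogen on an aromatic ring gives a 68-fold lower number from compound 1 to compound 3 (1.83 log units; beyond the scatter), a large step beyond the scatter. This place in the series is therefore not indifferent to ring size: replacing a three-membered carbon ring with a four-membered one is enough to produce a step of this size, even though neither group carries a hydrogen-bond donor, a hydrogen-bond acceptor or a net charge. Nothing available here accounts for the size of this step.

The compounds shown leave open whether cyclopentyl at this nitrogen would continue the fall, and whether a hydroxyl on the cyclobutyl or a morpholine in its place would recover the lost solubility. They also leave open whether the same swap has a similar effect on a differently substituted core.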